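Three Weak Agonists and a Fourth Awaiting Its Number

This account rests on a few compounds, and the source may have more. Where it says the series, first, only, none or still open, it means among the compounds named here.

Compound 1 `O=C(O)CC1COc2cc(OCc3ncc(-c4ccccc4)o3)ccc21`: 2.34%
Compound 2 `O=C(O)CC1COc2cc(OCc3nc(-c4ccccc4)cs3)ccc21`: 0.16%
Compound 3 `Cc1nc(-c2ccc(Cl)s2)sc1COc1ccc2c(c1)OCC2CC(=O)O`: 8.34%

In a functional assay on CHO cells for agonist activity at Free fatty acid receptor 1 (Homo sapiens), read by FLIPR and calcium flux, tested at 100 nM (a higher number here means a stronger effect of the compound at the concentration tested, a lower number a weaker effect), compound 3 gives 8.34%, the highest of the three numbers, but the gaps to compound 1 and to compound 2 both lie within the scatter, so the three compounds cannot be ranked against one another. Compound 4 `Cc1ccc(-c2nc(C)c(COc3ccc4c(c3)OCC4CC(=O)O)s2)cc1` shares the core of compound 3 and differs in one place: 4-methylphenyl in place of 5-chlorothiophen-2-yl on an aromatic carbon. Going by the values given here, no pair of measured compounds shows what a change of this kind does, so the direction is unknown. The step from compound 3 to compound 4 is expected to stay within the scatter, a number 2.3 percentage points lower from compound 3 to compound 4 (within the scatter). Compound 4 is estimated at 6%, between 0% and 20%.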

Compound 4, a percentage reported as activity, at one concentration (the size of the read-out at that concentration, not a potency): 54.9%
Compound 4: middle estimate off by 48.9 percentage points, on the low side; the measured number lies above the stated range.
By their numbers in this assay, from the lowest: compounds 2, 1 and 3 (each within the scatter of the next); then compound 4.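

In this assay the change from 5-chlorothiophen-2-yl to 4-methylphenyl gives a number 46.6 percentage points higher from compound 3 to compound 4 (beyond the scatter) and is the only step among these compounds that lies beyond the scatter. It shows that, on this aromatic carbon of the five-membered ring with 1 nitrogen and 1 sulfur, the choice of aromatic group can change the read-out at the concentration tested, at least for this pair. Nothing in the data gives a reason for the step.

Going by these compounds, whether a plain phenyl or a 4-chlorophenyl group at this place would hold the higher number stays open. So does whether the same change would carry over to the cores of compound 1 and compound 2.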